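The compounds below may be only part of what the source reports. "The series", "measured", "known", "first", "only" and "open" are said of these compounds alone.

Measured compounds:
Compound 1 `O=C(/C=C/c1ccccc1F)Nc1ccc(CC2=CC(=O)OC2)cc1`, 11.7%
Compound 2 `C=C1OC(=O)C=C1Cc1ccc(NC(=O)/C=C/c2ccc(F)cc2)cc1`, 94.1%
Compound 3 `O=C(/C=C/c1cccc(F)c1)Nc1ccc(CC2=CC(=O)OC2)cc1`, 13.1%

In an assay on isolated protein for inhibition of DNA topoisomerase 1 (Homo sapiens), with a stated time of 30 min, tested at 100 uM (a higher number here means more inhibition at the concentration tested (going by the name of the read-out), a lower number less inhibition), compound 2 stands highest of the three numbers; compound 3 lies a number 1.4 percentage points higher from compound 1 to compound 3 (within the scatter) from compound 1, and both sit far beneath compound 2. Among the compounds with values here, the core of compound 2 differs from that of compound 1 and compound 3, so no single step connects compound 2 to either of them; only their values can be set side by side.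

Compound 4 `C=C1OC(=O)C=C1Cc1ccc(NC(=O)/C=C/c2ccccc2)cc1` is obtained from compound 2 by hydrogen in place of fluoro on an aromatic carbon. Within the data shown here, the one measured step, from compound 1 to compound 3, moves the fluoro between ring positions and is within the scatter, which says little about removing it outright, and nothing measured concerns the core of compound 2. The high value of compound 2 is therefore the main anchor, with wide uncertainty. The expected step is a number 29.1 percentage points lower from compound 2 to compound 4 (beyond the scatter), a modest fall. Compound 4 is estimated at 65%, in the range 20% to 95%.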

Compound 4, a percentage reported as inhibition, at one concentration (the size of the read-out at that concentration, not a potency): 48.6%
The estimate for compound 4 lay 16.4 percentage points above the measured number; measured number inside the range.
By their numbers in this assay, from the lowest: compounds 1 and 3 (each within the scatter of the next); then compound 4; then compound 2.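

In this assay, the change from 4-fluorophenyl to phenyl gives a number 45.5 percentage points lower from compound 2 to compound 4 (beyond the scatter), which shows that on this core the fluoro on the aromatic carbon para to a large group carries a large part of the read-out. The earlier step, a number 1.4 percentage points higher from compound 1 to compound 3 (within the scatter), only moved a fluoro around the ring on a different core and gave no sign of this. The loss is not complete, as compound 4 still gives 48.6%, and nothing available bears on why the fluoro matters here.

The compounds shown leave open whether chloro, methoxy or an amine at this position would match compound 2 at 94.1%. They also leave open how a fluoro placed elsewhere on the ring would read on this core.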